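A few compounds are considered here, and "the series" means these few. Any claim that something is new, unique, unknown or untested is made for them only; others in the source may bear on it.

The shared core is seen in compound 1 `C=C1CC[C@H]2[C@@](C)(CCC(=O)N[C@@]2(C)COC(=O)CCCC[C@@H]2CCSS2)[C@@H]1/C=C/C1=CCOC1=O`, which in an assay for inhibition of hexokinase-2 (Homo sapiens), read by coupled enzyme assay, with a stated time of 10 min, in the presence of a further agent that is not named here (a lower number here means a stronger inhibitor, a higher number a weaker inhibitor), gives 9360 nM. Compound 2 `C=C1CC[C@H]2[C@@](C)(CC[C@@H](O)[C@@]2(C)NC=O)[C@@H]1/C=C/C1=CCOC1=O` carries a hydroxy group on the core in place of the ester-bearing chain of compound 1. In this assay compound 2 reaches only the limit > 50000 nM, so no number is known for it, and it stands at the limit of > 50000 nM in this assay, at which 1 of the 2 values shown sits. Compound 3 `C=C1CC[C@H]2[C@@](C)(CC[C@@H](OC(=O)CNC)[C@@]2(C)NC=O)[C@@H]1/C=C/C1=CCOC1=O` differs from compound 2 by ((methylamino)methyl)carbonyl in place of hydrogen on an oxygen on a saturated carbon. Within the data shown here, no measured step of this kind is available in this assay, so its size can only be estimated. Compound 1 likewise carries an ester on the core and gives 9360 nM. On that footing compound 3 is expected to move downward, an at least 1.6-fold lower number from compound 2 to compound 3 (0.22 log units; that floor lies within the scatter), though a value beyond the limit would not surprise. For compound 3 the estimated half-maximal inhibitory concentration in this assay is 30000 nM, with a range from 8000 nM to 100000 nM.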

Compound 3, half-maximal inhibitory concentration: > 50000 nM
Compound 3: no number, only a limit; the forecaster's own chance of this, stated with the estimate: 50%; middle value at least 1.6-fold (0.22 log units) from the limit.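

No new step can be read from compound 2 to compound 3, since in this assay both give only a limit and no number: the limit of > 50000 nM in this assay, at which 2 of the 3 values shown sit. The compounds shown leave open whether ((methylamino)methyl)carbonyl in place of hydrogen on that oxygen changes inhibition at all.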